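Swapping ethyl for chloro on the sulfonamide side

This account rests on a few compounds, and the source may have more. Where it says the series, first, only, none or still open, it means among the compounds named here.

The compounds measured so far in a functional assay on DU-145 cells (Homo sapiens) for antiproliferative activity, read by sulforhodamine B assay, with a stated time of 48 h (on this read-out higher numbers stand for weaker inhibition and lower numbers for stronger inhibition), are these:
compound 1 `O=C1NCCN1c1ccc(S(=O)(=O)Nc2ccc3[nH]ccc3c2)cc1` gives 1370 nM
compound 2 `CCc1cccc(NS(=O)(=O)c2ccc(N3CCNC3=O)cc2)c1` gives 730 nM
compound 3 `Cc1ccc(C)c(NS(=O)(=O)c2ccc(N3CCNC3=O)cc2)c1` gives 1610 nM

Compound 2 at 730 nM sits within the usual scatter of compound 1, and only compound 3 lies beyond the scatter from it, on the higher side.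

The next compound is compound 4 `O=C1NCCN1c1ccc(S(=O)(=O)Nc2cccc(Cl)c2)cc1`, which keeps the rest of compound 2 and carries chloro in place of ethyl on an aromatic carbon, meta to a large group (chloro in place of ethyl on an aromatic carbon). In other words, 3-ethylphenyl becomes 3-chlorophenyl.

Among the measured compounds shown here, no measured pair makes this exact swap. The closest evidence is a 2.2-fold higher number from compound 2 to compound 3 (0.34 log units; beyond the scatter), where 2,5-dimethylphenyl replaces 3-ethylphenyl on a sulfonamide nitrogen. For the measured compounds named here, that modest step only just clears the scatter, and it is the sole guide here, so a large change would be a surprise.

The expected result is a 1.4-fold higher number from compound 2 to compound 4 (0.14 log units; within the scatter) in this assay, which would stay within the scatter and lean slightly toward a higher number. For compound 4 the estimated value is 1000 nM, with an expected range from 400 nM to 2200 nM.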

Compound 4, half-maximal inhibitory concentration: 230 nM
Beside the measured number, compound 4's estimate is 4.3-fold (0.64 log units) above it; the whole stated range lies above it.
By their numbers in this assay, from the lowest: compound 4; then compounds 2, 1 and 3 (each within the scatter of the next, the first and the last beyond it).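

In this assay, exchanging 3-ethylphenyl for 3-chlorophenyl gives a 3.2-fold lower number from compound 2 to compound 4 (0.50 log units; beyond the scatter), which shows that this aromatic carbon is sensitive to the group it carries, even when the change is as small as chloro for ethyl. The same 3-chlorophenyl group, set against the 2,5-dimethylphenyl group on the sulfonamide nitrogen, gives a 7.0-fold lower number from compound 3 to compound 4 (0.85 log units; beyond the scatter), so changes to this group can now be seen to move the number in either direction, where the earlier step had shown only a rise. The data offer no measurement that explains why chloro gives stronger inhibition than ethyl in this series.

From the compounds shown here alone, it remains open whether this gain is particular to chloro or would also appear with another small group on the same aromatic carbon, such as fluoro, methoxy or a nitrile. The compounds shown also leave open whether chloro would give a similar result elsewhere on this ring, and whether the step would hold in a different core.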